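Para-halogen swap on the shared core: fluoro to bromo

The source may report more compounds than this note shows. Statements on the series, on what has been measured and on what is new or still open speak of the compounds shown alone.

Of the compounds shown here, three sharing one core have been tested in a functional assay on HepG2 cells (Homo sapiens) for inhibition, read by MTT assay, with a stated time of 72 h; on this read-out lower numbers stand for stronger inhibition and higher numbers for weaker inhibition. Compound 1 `C#CCSc1nc(Nc2ccc(F)cc2)c2ccncc2n1` gives 10800 nM, the lowest of the three numbers. Compound 2 `C#CCSc1nc(Nc2ccccc2Cl)c2ccncc2n1` gives 17200 nM, and the step of a 1.6-fold higher number from compound 1 to compound 2 (0.20 log units; within the scatter) lies within the scatter. Compound 3 `C#CCSc1nc(Nc2ccc(Cl)cc2)c2ccncc2n1` gives 36700 nM; the step of a 3.4-fold higher number from compound 1 to compound 3 (0.53 log units; beyond the scatter) is a modest weakening, and the step of a 2.1-fold higher number from compound 2 to compound 3 (0.33 log units; beyond the scatter) points the same way.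

Compound 4 `C#CCSc1nc(Nc2ccc(Br)cc2)c2ccncc2n1` has not yet been measured. It differs from compound 1 in one place: bromo in place of fluoro on an aromatic carbon. Within the data shown here, only one measured step bears directly on this change, the exchange of fluoro for chloro on the same aromatic carbon, which gave a 3.4-fold higher number from compound 1 to compound 3 (0.53 log units; beyond the scatter). Bromo is the third halogen in that series, and the one measured step offers the nearest guide; no measured pair shows chloro against bromo here, so the expected size rests on a single comparison. On that basis compound 4 is expected to be weaker than compound 1, with a step of about a 3.7-fold higher number from compound 1 to compound 4 (0.57 log units; beyond the scatter), in the same direction as the move to compound 3 and of at least that size. The estimate for compound 4 in this assay is therefore 40000 nM, with a range from 15000 nM to 110000 nM.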

Compound 4, half-maximal inhibitory concentration: 56200 nM
For compound 4 the middle estimate is 1.4-fold (0.15 log units) below the measured one; low and high end bracket the measured number.
By their numbers in this assay, from the lowest: compounds 1 and 2 (each within the scatter of the next); then compounds 3 and 4 (each within the scatter of the next).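

On this aromatic carbon, bromo in place of fluoro gives a 5.2-fold higher number from compound 1 to compound 4 (0.72 log units; beyond the scatter) and so moves the number in the same direction as chloro did, which means that two different halogens now read weaker than fluoro. The new compound also shows that the two heavier halogens cannot be separated here, since a 1.5-fold higher number from compound 3 to compound 4 (0.19 log units; within the scatter) gives no ranking of chloro against bromo and the measured change is a single gap between fluoro and this pair, not a steady climb through the series. The 4-bromophenyl group also reads weaker than the 2-chlorophenyl group, with a 3.3-fold higher number from compound 2 to compound 4 (0.51 log units; beyond the scatter) showing that the halogen on this carbon of the ring gives a higher number than chloro on the ring position of compound 2, whose own number remains within the scatter of compound 1.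

As far as these compounds go, it remains open how an unsubstituted phenyl ring, or a methoxy group, an amine or a carboxylic acid on the same carbon, would compare with fluoro, and whether any of them would give a lower number. No measurement offered here explains why the number changes with these halogens.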